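The source may hold more compounds than are shown below. What is called first, only, known or untested is meant among the compounds shown, and "the series" means these compounds.

The measured compounds so far:

Compound 1 `O=C(O)Cn1nc(CC(=O)Nc2ccc(OC(F)(F)F)c(Cl)c2)c2ccccc2c1=O` gives 389 nM in a functional assay on CHO cells for antagonist activity at sphingosine 1-phosphate receptor 2 (Homo sapiens), read by calcium flux; a lower number here means a stronger inhibitor, a higher number a weaker inhibitor.
Compound 2 `CCn1nc(CC(=O)Nc2ccc(OC(F)(F)F)c(Cl)c2)c2ccccc2c1=O` gives 199 nM in this assay.
Compound 3 `COc1cc2[nH]c(Cc3nn(CC(=O)O)c(=O)c4ccccc34)nc2cc1Cl` gives 61 nM in this assay.

Compound 3 stands lowest of the three numbers; compound 2 is the nearest to it and compound 1 the furthest, and both gaps are beyond the usual scatter. Compound 4 `O=C(O)Cn1nc(Cc2nc3cc(Cl)c(OC(F)(F)F)cc3[nH]2)c2ccccc2c1=O` differs from compound 3 in one place: trifluoromethyl in place of methyl on an oxygen on an aromatic ring. Among the measured compounds shown here, the only measured single-point step, a 2.0-fold lower number from compound 1 to compound 2 (0.29 log units; within the scatter), concerns a different place, a saturated chain carbon bound to an aromatic nitrogen, and lies within the scatter; it says nothing direct about an exchange on an oxygen on an aromatic ring. For the measured compounds named here, compounds 1 and 2 already carry trifluoromethoxy but differ from compound 3 in more than that one place, so their values show only that compound 3 is the lower of the group. Going by the values given here, with no step bearing on this change, one expects for compound 4 a step of about a 1.1-fold higher number from compound 3 to compound 4 (0.06 log units; within the scatter) in this assay, none beyond the scatter. The estimate for compound 4 is 70 nM, with a range from 25 nM to 200 nM.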

Compound 4, half-maximal inhibitory concentration: 31 nM
Beside the measured number, compound 4's estimate is 2.3-fold (0.35 log units) above it, within the range that was stated.
By their numbers in this assay, from the lowest: compounds 4 and 3 (each within the scatter of the next); then compounds 2 and 1 (each within the scatter of the next).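

Among the compounds shown here, exchanging methoxy for trifluoromethoxy on this oxygen gives, in this assay, a 2.0-fold lower number from compound 3 to compound 4 (0.29 log units; within the scatter), and this is the first direct reading of the change, since compounds 1 and 2 carry trifluoromethoxy but differ from compound 3 in more than that one place. The step lies within the scatter, so at this place on this core trifluoromethyl can stand in for methyl with no difference that this read-out can separate. Nothing shown here offers a reason for this outcome.

As far as these compounds go, whether difluoromethyl, ethyl or a plain hydroxy at this place would read the same remains open. So does whether the exchange of carboxy for methyl on the saturated chain carbon, read so far only on the core of compound 1, would behave alike on the core of compound 4.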